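A few compounds are considered here, and "the series" means these few. Any claim that something is new, unique, unknown or untested is made for them only; others in the source may bear on it.

Measured so far in a functional assay for inhibition of sodium/hydrogen exchanger (Oryctolagus cuniculus); a lower number here means a stronger inhibitor, a higher number a weaker inhibitor:
compound 1 `Cc1c(C(=O)N=C(N)N)cc(S(C)(=O)=O)c(Cl)c1C` — compound 1 gives 58 nM
compound 2 `CCN(CC)Cc1cc(Br)c(S(C)(=O)=O)cc1C(=O)N=C(N)N` — compound 2 gives 9500 nM
compound 3 `Cc1cc(C2CCC2)c(S(C)(=O)=O)cc1C(=O)N=C(N)N` — compound 3 gives 8.2 nM

Of the three, compound 3 stands at the lowest number in this assay; its gap to compound 1 and its gap to compound 2 both lie beyond the usual scatter, so compound 3 is the strongest inhibitor among the measured compounds. No pair of these compounds differs in a single place, so no single-step comparison is available, and nothing in the measured set tests the change now considered.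

Compound 4 `Cc1cc(Sc2ccncc2)c(S(C)(=O)=O)cc1C(=O)N=C(N)N` is the next compound for this assay. It differs from compound 3 in one place: (pyridin-4-yl)sulfanyl in place of cyclobutyl on an aromatic carbon. The group that enters is larger than the group that leaves and brings hydrogen-bond acceptors where there were none. Nothing measured here shows what a change of this kind does, so the expectation rests on the standing of compound 3 alone.

The step from compound 3 to compound 4 is expected to go toward a higher number, beyond the scatter, at a 7.3-fold higher number from compound 3 to compound 4 (0.86 log units; beyond the scatter). For compound 4 the estimate in this assay is 60 nM, with a range from 10 nM to 400 nM; a number within the scatter of compound 3 cannot be excluded.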

Compound 4, half-maximal inhibitory concentration: 13 nM
Estimate against measurement, compound 4: 4.6-fold (0.66 log units) above; measured number inside the range.
By their numbers in this assay, from the lowest: compounds 3 and 4 (each within the scatter of the next); then compound 1; then compound 2.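

In this assay, the step on the aromatic carbon ortho to a methylsulfonyl group, with (pyridin-4-yl)sulfanyl in place of cyclobutyl, is a 1.6-fold higher number from compound 3 to compound 4 (0.20 log units; within the scatter). Among the compounds shown here, this is the first comparison that changes a single place, and it shows that this position can carry a group of 7 heavy atoms, with a six-membered aromatic ring and hydrogen-bond acceptors, as well as a four-membered carbon ring of 4 heavy atoms, with no difference that this measurement can resolve. The measurements at hand give no account of why two such different groups read alike here.

Still open, from the compounds shown here alone, is which part of the entering group matters at this position, the sulfur link or the ring nitrogen: phenylsulfanyl would test the ring nitrogen with the sulfur link kept, and (pyridin-4-yl)oxy would test the link with the ring kept. Also open, going by these compounds, is how far this tolerance extends to other kinds of group on the same carbon, such as a piperidin-1-yl amine or a carboxylic acid.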